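The compounds below may be only part of what the source reports. "The series", "measured", "known", "first", "only" and "open" are said of these compounds alone.

Compound 1: `O=C1C=C(Nc2cccc(Cl)c2)C(=O)c2c1nc1n2[C@H]2OC[C@@H](O)[C@H]2OC1`, in a functional assay on MCF7 cells (Homo sapiens) for inhibition, read by sulforhodamine B assay (on this read-out lower numbers stand for stronger inhibition and higher numbers for weaker inhibition), compound 1 gives 4720 nM.
Compound 2: `CCOc1ccccc1NC1=CC(=O)c2nc3n(c2C1=O)[C@H]1OC[C@@H](O)[C@H]1OC3`, for compound 2 this assay reports only a limit, > 4000 nM.
Compound 3: `O=C1C(Nc2ccc(Br)cc2)=CC(=O)c2c1nc1n2[C@H]2OC[C@@H](O)[C@H]2OC1`, compound 3 gives 4330 nM.

Among the two numbers shown, compound 1 carries the higher one, yet its gap to compound 3 lies within the scatter, so the two cannot be ordered. The move from compound 1 to compound 2, a step that the limit leaves unreadable from compound 1 to compound 2, cannot be read in size because of the limit of > 4000 nM in this assay, at which 1 of the 3 values shown sits. Compound 4, `O=C1C=C(N2CCC2)C(=O)c2c1nc1n2[C@H]2OC[C@@H](O)[C@H]2OC1`, has not been measured. It differs from compound 1 by azetidin-1-yl in place of (3-chlorophenyl)amino on a double-bonded ring carbon. Among the compounds with values here, no measured step follows this kind of change, so no direction can be taken from the set; the change is expected to stay within the scatter, a 1.3-fold higher number from compound 1 to compound 4 (0.10 log units; within the scatter). Compound 4 is therefore estimated at 6000 nM, between 2000 nM and 20000 nM.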

Compound 4, half-maximal inhibitory concentration: > 16000 nM
Compound 4: no number, only a limit; the forecaster's own chance of this, stated with the estimate: 40%; at least 2.6-fold (0.42 log units) between middle value and limit.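

In this assay, compound 4 gives only a limit, > 16000 nM. Even so, azetidin-1-yl in place of (3-chlorophenyl)amino on this double-bonded ring carbon produces an at least 3.3-fold higher number from compound 1 to compound 4 (0.53 log units; beyond the scatter), the first step in the set that can be read as beyond the scatter. The number at this place therefore does respond to the group it carries, and this change moves it towards weaker inhibition.

Which part of the change counts remains open: the donor hydrogen and the aromatic ring leave together. A cyclohexylamino group, keeping the nitrogen hydrogen without the aromatic ring, would separate the two.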